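Nitro in place of fluoro: compound 2 to compound 4

A few compounds are considered here, and "the series" means these few. Any claim that something is new, unique, unknown or untested is made for them only; others in the source may bear on it.

Compound 2 `O=C1/C(=C/c2ccccc2F)Cc2ccccc21` gives 31700 nM in a functional assay on P388 cells (Mus musculus) for inhibition (a lower number here means a stronger inhibitor, a higher number a weaker inhibitor), the highest of the three numbers in hand. Compound 1 `O=C1/C(=C/c2ccccc2Cl)Cc2ccccc21` gives 26500 nM, and the step of a 1.2-fold higher number from compound 1 to compound 2 (0.08 log units; within the scatter) lies within the scatter. Compound 3 `O=C1/C(=C/c2ccccc2[N+](=O)[O-])CCc2ccccc21`, a nitro compound on a different core, gives 12600 nM, a lower number than compound 2 beyond the scatter. Compound 4 `O=C1/C(=C/c2ccccc2[N+](=O)[O-])Cc2ccccc21` differs from compound 2 by nitro in place of fluoro on an aromatic carbon. Going by the values given here, no measured step shows this change on the shared core; the step from compound 1 to compound 2 concerns halogens only. Compound 4 is nevertheless expected to give a somewhat lower number, a 2.0-fold lower number from compound 2 to compound 4 (0.30 log units; within the scatter), because compound 3 gives 12600 nM. The estimate for compound 4 in this assay is 16000 nM, range 6000 nM to 40000 nM.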

Compound 4, half-maximal inhibitory concentration: 740 nM
For compound 4 the middle estimate is 22-fold (1.33 log units) above the measured one; measured number outside the range, below it.
By their numbers in this assay, from the lowest: compound 4; then compound 3; then compounds 1 and 2 (each within the scatter of the next).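

On the shared core in this assay, the swap between the two halogens moved nothing beyond the scatter, yet nitro in place of fluoro gives a 43-fold lower number from compound 2 to compound 4 (1.63 log units; beyond the scatter) and nitro in place of chloro gives a 36-fold lower number from compound 1 to compound 4 (1.55 log units; beyond the scatter) on that same core. This position on the aromatic ring therefore responds strongly to the identity of the group, which the halogen pair alone did not reveal. Nothing in hand explains the size of these steps.

As far as these compounds go, whether an amine or a carboxylic acid at this position would keep the low number remains open. Also open, from the compounds shown here alone, is whether a fluoro or chloro counterpart of compound 3 would show a step of similar size on that core.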